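The compounds below may be only part of what the source reports. "The series", "measured", "known", "first", "only" and "open" are said of these compounds alone.

Measured in a functional assay on K562 cells (Homo sapiens) for inhibition, read by fluorescence, with a stated time of 72 h; on this read-out higher numbers stand for weaker inhibition of growth and lower numbers for stronger inhibition of growth:
- Compound 1 `COc1ccc(Nc2nc(N[C@H]3CC[C@H](N)CC3)nc3c2ncn3CCC(C)C)c(OC)c1`: 5500 nM
- Compound 2 `CCCCCCn1cnc2c(Nc3cc(OC)cc(OC)c3)nc(N[C@H]3CC[C@H](N)CC3)nc21`: 1900 nM
- Compound 3 `CCCCCCn1cnc2c(Nc3ccc(O)cc3)nc(N[C@H]3CC[C@H](N)CC3)nc21`: 5400 nM

Compound 3 at 5400 nM and compound 1 at 5500 nM lie within the scatter of each other, and compound 2 shows a lower number, 1900 nM. Compound 4 `CC(C)CCn1cnc2c(Nc3cccc(Cl)c3)nc(N[C@H]3CC[C@H](N)CC3)nc21` keeps the rest of compound 1 and alters one group: 3-chlorophenyl in place of 2,4-dimethoxyphenyl on a nitrogen on an aromatic ring.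

Going by the values given here, only one measured step bears on this change: a 2.8-fold higher number from compound 2 to compound 3 (0.45 log units; beyond the scatter). It is a modest swap of one group for another on that same kind of nitrogen, but it involves neither group of the present change and comes from compounds with another chain. Among the compounds with values here, it therefore suggests a possible size but no direction, since no measured compound carries the 3-chlorophenyl group. In this assay, no step beyond the scatter is expected as the likeliest outcome.

The estimate means a 1.6-fold lower number from compound 1 to compound 4 (0.20 log units; within the scatter), a small expected step. Compound 4 is estimated at 3500 nM, with an expected range from 1200 nM to 9000 nM.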

Compound 4, concentration for 50% growth inhibition: 1500 nM
Compound 4: middle estimate off by 2.3-fold (0.37 log units), on the high side; the range from low to high includes it.
By their numbers in this assay, from the lowest: compounds 4 and 2 (each within the scatter of the next); then compounds 3 and 1 (each within the scatter of the next).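

In this assay the change at this nitrogen gives a 3.7-fold lower number from compound 1 to compound 4 (0.56 log units; beyond the scatter), a step beyond the scatter. Going by these compounds alone, this is the first measured step at this place on the chain of compound 1, and it shows that the number there also moves with the group on the nitrogen, not only on the chain of compounds 2 and 3. The step swaps a group with two hydrogen-bond acceptors for one with none and brings in chlorine, but no measurement on hand accounts for the step or shows which of these differences matters.

The compounds shown leave open whether the chlorine itself matters or whether a plain phenyl, or a bromine or a methyl group in its stead, would give a similar number. They also leave open whether the 3-chlorophenyl group would bring a similar step on the chain of compound 2.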